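The source may hold more compounds than are shown below. What is called first, only, known or untested is meant among the compounds shown, and "the series" means these compounds.

Series values in a functional assay on NCI-H460 cells (Homo sapiens) for antiproliferative activity, read by MTT assay, with a stated time of 48 h; a higher number here means a weaker inhibitor, a lower number a stronger inhibitor:

Compound 1 `COc1ccc(-c2nc3cccc(-c4cc(OC)c(OC)c(OC)c4)c3o2)cc1`: 3500 nM
Compound 2 `COc1ccc(-c2nc3cccc(-c4cc(OC)c(OC)c(OC)c4)c3o2)cc1F`: 2800 nM
Compound 3 `COc1cc(-c2nc3cccc(-c4cc(OC)c(OC)c(OC)c4)c3o2)ccc1O`: 2000 nM

Compound 3 is not separated from the other two compounds in this assay. Both a 1.8-fold lower number from compound 1 to compound 3 (0.24 log units; within the scatter) and a 1.4-fold lower number from compound 2 to compound 3 (0.15 log units; within the scatter) stay within the usual scatter, so the three values form a single group.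

The next compound is compound 4 `COc1cc(-c2cccc3nc(-c4cccs4)oc23)cc(OC)c1OC`, with thiophen-2-yl in place of 4-hydroxy-3-methoxyphenyl on an aromatic carbon. The three measured steps all concern the aryl group at this same place. Besides the two steps to compound 3, a 1.3-fold lower number from compound 1 to compound 2 (0.10 log units; within the scatter) is also small and within the scatter. These steps give no sign that edits at this place move the number much. However, all three only alter substituents on a six-membered aromatic ring of carbon only. For the measured compounds named here, none replaces that ring with a five-membered aromatic ring with 1 hetero atom, so the data offer no direct precedent for this change, and the range has to stay wide.

No clear shift beyond the scatter is expected, with only a slight lean towards a higher number. The expected step is a 1.5-fold higher number from compound 3 to compound 4 (0.18 log units; within the scatter). For compound 4 the estimated value is 3000 nM, with an expected range from 1000 nM to 10000 nM.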

Compound 4, half-maximal inhibitory concentration: 1600 nM
For compound 4 the middle estimate is 1.9-fold (0.27 log units) above the measured one; the measured number falls inside the stated range.
By their numbers in this assay, from the lowest: compounds 4, 3, 2 and 1 (each within the scatter of the next, the first and the last beyond it).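

In this assay the thiophen-2-yl group is accepted on this aromatic carbon of the five-membered aromatic ring with 1 nitrogen and 1 oxygen, and this is the first replacement of the six-membered aromatic ring of carbon only: the series shows a 1.3-fold lower number from compound 3 to compound 4 (0.10 log units; within the scatter) and a 1.8-fold lower number from compound 2 to compound 4 (0.24 log units; within the scatter), so the change of ring size gives no step beyond the scatter from either of these compounds, even with 5 heavy atoms entering for 9 and 0 hydrogen-bond donors for 1 in the step from compound 3. The series also now holds its first step beyond the scatter, a 2.2-fold lower number from compound 1 to compound 4 (0.34 log units; beyond the scatter), although this step is modest and compound 4 stays within the scatter of compounds 2 and 3. No supporting measurement is available to explain these results.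

Open, as far as these compounds go, is whether furan-2-yl or a pyridine ring would read like thiophen-2-yl here, and whether an amine or a carboxylic acid carried on the thiophene ring would move the number. From the compounds shown here alone, all four compounds share the rest of the core, so edits elsewhere on it remain unknown in this assay and could behave differently.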